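The source may report more compounds than this note shows. Statements on the series, on what has been measured and on what is new or still open speak of the compounds shown alone.

Compound 2 `CC(C)=CC[C@@H](OC(=O)C1CCOC1)C1=CC(=O)c2c(O)ccc(O)c2C1=O` gives the highest number of the three measured compounds in a functional assay on DU-145 cells (Homo sapiens) for cytotoxicity, read by MTT assay (on this read-out higher numbers stand for weaker inhibition and lower numbers for stronger inhibition), at 47500 nM. Compound 1 `CC(=O)OCCO[C@H](CC=C(C)C)C1=CC(=O)c2c(O)ccc(O)c2C1=O` stands nearest, with 15500 nM in this assay, the step being a 3.1-fold higher number from compound 1 to compound 2 (0.49 log units; beyond the scatter). Compound 3 `CC(C)=CC[C@@H](OCCO)C1=CC(=O)c2c(O)ccc(O)c2C1=O` gives 9900 nM in this assay, and the step from the acetylated to the free hydroxyl is a 1.6-fold lower number from compound 1 to compound 3 (0.19 log units; within the scatter). The step of a 4.8-fold lower number from compound 2 to compound 3 (0.68 log units; beyond the scatter) is the largest of the three.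

Compound 4 `CC(=O)OC(C)CO[C@H](CC=C(C)C)C1=CC(=O)c2c(O)ccc(O)c2C1=O` is not yet measured in this assay. It differs from compound 2 in one place: 2-acetoxypropyl in place of (oxolan-3-yl)carbonyl on an oxygen on a saturated carbon. The entering group is an open chain ester of the same size as the 2-acetoxyethyl of compound 1, with one more methyl on the chain. Going by the values given here, the steps that bear on this are a 3.1-fold higher number from compound 1 to compound 2 (0.49 log units; beyond the scatter) and a 4.8-fold lower number from compound 2 to compound 3 (0.68 log units; beyond the scatter); both show that replacing the (oxolan-3-yl)carbonyl by an open-chain group on that oxygen gives a lower number. The step of a 1.6-fold lower number from compound 1 to compound 3 (0.19 log units; within the scatter) shows the acetyl itself matters little. A modest drop is therefore expected, close to compound 1.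

For compound 4 the estimate in this assay is 17000 nM, with a range of 8000 nM to 36000 nM; the expected step is a 2.8-fold lower number from compound 2 to compound 4 (0.45 log units; beyond the scatter).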

Compound 4, half-maximal inhibitory concentration: 16600 nM
Compound 4: middle estimate off by 1.0-fold (0.01 log units), on the high side; the range from low to high includes it.
By their numbers in this assay, from the lowest: compounds 3, 1 and 4 (each within the scatter of the next); then compound 2.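

In this assay, the open-chain 2-acetoxypropyl on this oxygen again stands apart from the (oxolan-3-yl)carbonyl (a 2.9-fold lower number from compound 2 to compound 4 (0.46 log units; beyond the scatter)), although the counts of heavy atoms, hydrogen-bond donors and hydrogen-bond acceptors match between the two groups. The extra methyl on the chain leaves compound 4 within the scatter of compound 1 (a 1.1-fold higher number from compound 1 to compound 4 (0.03 log units; within the scatter)), and the ester-bearing chain of compound 4 is also within the scatter of the free hydroxyl of compound 3 (a 1.7-fold higher number from compound 3 to compound 4 (0.22 log units; within the scatter)). No measurement at hand gives a reason for the gap separating compound 2 from the open-chain compounds.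

Going by these compounds, the (oxolan-3-yl)carbonyl differs from these chains in both its ring and its carbonyl on the oxygen, so whether either alone tracks the gap stays open; an open-chain pentanoyl on this oxygen would separate the two. Where a 2-aminoethyl group or a longer chain would stand in this assay also remains open.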